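The source may report more compounds than this note shows. Statements on the series, on what has been measured and on what is new or still open speak of the compounds shown alone.

Three compounds that differ in one group on a shared core have been tested in a functional assay on L1210 cells (Mus musculus) for inhibition; on this read-out lower numbers stand for stronger inhibition and higher numbers for weaker inhibition. Compound 1 `O=c1[nH]c(=O)n(C2O[C@H](CCl)[C@@H](O)[C@H]2O)cc1F` carries chloro on a saturated chain carbon bound to a saturated ring carbon and gives 3400 nM. Compound 2 `O=c1[nH]c(=O)n(C2O[C@H](CBr)[C@@H](O)[C@H]2O)cc1F` has bromo in that place and gives 800 nM. Compound 3 `[N-]=[N+]=NC[C@H]1OC(n2cc(F)c(=O)[nH]c2=O)[C@H](O)[C@@H]1O` has azido there and gives 170000 nM, the highest number of the three and so the weakest inhibition.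

The next compound is compound 4 `O=c1[nH]c(=O)n(C2O[C@H](CF)[C@@H](O)[C@H]2O)cc1F`, and the change is fluoro in place of azido on a saturated chain carbon bound to a saturated ring carbon. In words, this is fluoro in place of azido on a saturated chain carbon bound to a saturated ring carbon.

Going by the values given here, no measured step makes this exact swap, but three steps bear on it. Two large steps separate azido from the other groups: a 50-fold higher number from compound 1 to compound 3 (1.70 log units; beyond the scatter) and a 210-fold higher number from compound 2 to compound 3 (2.33 log units; beyond the scatter). The step between the two halogens is only modest: a 4.3-fold lower number from compound 1 to compound 2 (0.63 log units; beyond the scatter). Fluoro is also a halogen, so it should sit nearer to chloro and bromo than to azido, although no fluoro compound has yet been measured to confirm this.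

A large drop in this assay is therefore expected, a 28-fold lower number from compound 3 to compound 4 (1.45 log units; beyond the scatter). Compound 4 is estimated at 6000 nM, with an expected range of 1200 nM to 40000 nM.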

Compound 4, half-maximal inhibitory concentration: 29000 nM
Estimate against measurement, compound 4: 4.8-fold (0.68 log units) below, within the range that was stated.
By their numbers in this assay, from the lowest: compound 2; then compound 1; then compound 4; then compound 3.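

Fluoro recovers only part of what azido loses in this assay (a 5.9-fold lower number from compound 3 to compound 4 (0.77 log units; beyond the scatter)), and it does not join the other two halogens: the swaps from them give (an 8.5-fold higher number from compound 1 to compound 4 (0.93 log units; beyond the scatter)) and (a 36-fold higher number from compound 2 to compound 4 (1.56 log units; beyond the scatter)). The chloro and bromo pair alone gave only a modest step (a 4.3-fold lower number from compound 1 to compound 2 (0.63 log units; beyond the scatter)), so it suggested a narrow spread among halogens at this place, whereas the three halogens together cover a much wider spread, with the numbers rising from bromo through chloro to fluoro. Being a halogen therefore does not settle the outcome here, although azido still gives the weakest inhibition of the four and bromo the strongest.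

From the compounds shown here alone, whether iodo would carry the halogen order on to lower numbers remains open, as does what a hydroxyl, an amine or a longer chain would give on this saturated chain carbon. The numbers show the order of these groups but not what lies behind it, and no supporting measurement is available to explain it.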